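From an Amine Side Chain to an Amide

The source may hold more compounds than are shown below. What is called first, only, known or untested is meant among the compounds shown, and "the series" means these compounds.

Compound 1 `CCN(CC)c1ccc(NC(=O)c2c(-c3c(Cl)cccc3Cl)noc2CCC2OCCCO2)c(C)c1`, compound 2 `CCN(CC)c1ccc(NC(=O)c2c(-c3c(Cl)cccc3Cl)noc2C)c(C)c1` and compound 3 `CCN(CC)Cc1ccc(NC(=O)c2c(-c3c(Cl)cccc3Cl)noc2C)cc1` share one core and were tested in an assay on isolated protein for binding affinity to growth hormone secretagogue receptor type 1 (Homo sapiens); on this read-out lower numbers stand for stronger inhibition and higher numbers for weaker inhibition. Compound 1 gives 9 nM, and compound 2 gives 37 nM; the step of a 4.1-fold higher number from compound 1 to compound 2 (0.61 log units; beyond the scatter) concerns a chain on the far side of the core. Compound 3 stands apart. In this assay compound 3 gives > 10000 nM, which is a limit of the test and not a number. Compound 3 therefore sits at the limit of > 10000 nM in this assay, at which 1 of the 3 values shown sits, the weak end of everything measured here.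

Compound 4 `CCN(C(C)=O)c1ccc(NC(=O)c2c(-c3c(Cl)cccc3Cl)noc2C)cc1` has not yet been measured. It differs from compound 3 by acetyl(ethyl)amino in place of (diethylamino)methyl on an aromatic carbon. Within the data shown here, no measured step touches this part of the molecule: the only measured step lies on the other side of the core and gives no guide to the size or direction of this change. The nearest hint is that compound 2, which carries a nitrogen directly on that ring, gives 37 nM. Compound 3, which carries (diethylamino)methyl instead, reaches only a limit of the test. Compound 4 is therefore expected to recover some binding, estimated at 1500 nM with a range from 150 nM to 10000 nM. The expected step of an at least 6.6-fold lower number from compound 3 to compound 4 (0.82 log units; beyond the scatter) is a gain, though with a real chance of another limit.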

Compound 4, half-maximal inhibitory concentration: > 10000 nM
Compound 4: a limit, no number; the forecaster's own chance of this, stated with the estimate: 30%; middle value at least 6.6-fold (0.82 log units) from the limit.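

In this assay compound 4 gives > 10000 nM as a limit of the test and not a number. Among these compounds, compound 3 sits at the same limit, so no step from compound 3 to compound 4 can be read: the limit of > 10000 nM in this assay, at which 2 of the 4 values shown sit. The compounds shown leave open how acetyl(ethyl)amino and (diethylamino)methyl really compare in binding.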